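Methyl for methoxy on the shared core: expected lipophilicity

The compounds below may be only part of what the source reports. "The series", "measured", "known", "first", "only" and "open" are said of these compounds alone.

Compound 2 `COc1cc(-c2c(C)nn(C)c2C)ccc1-c1nnc(N(C)Cc2ccc3nccn3c2)o1` gives 2.9 in a physicochemical assay for lipophilicity, at pH 7.4 (a lower number here means a more polar compound, a higher number a more lipophilic compound), the lower of the two numbers measured, while compound 1 `Cc1nn(C)c(C)c1-c1ccc(-c2nnc(N(C)Cc3ccc4nccn4c3)o2)c(Cl)c1` gives 3.3. For the measured compounds named here, the one measured step, a number 0.40 log units lower from compound 1 to compound 2 (beyond the scatter), runs the other way from the change now considered. Compound 3 `Cc1cc(-c2c(C)nn(C)c2C)ccc1-c1nnc(N(C)Cc2ccc3nccn3c2)o1` differs from compound 2 by methyl in place of methoxy on an aromatic carbon. Going by the values given here, no measured pair compares methyl with methoxy, so the step of a number 0.40 log units higher from compound 2 to compound 3 (beyond the scatter) is an expectation only, a modest rise drawn from the size of a number 0.40 log units lower from compound 1 to compound 2 (beyond the scatter). Compound 3 is therefore estimated at 3.3, with a range from 2.9 to 3.7.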

Compound 3, distribution coefficient: 3.7
Beside the measured number, compound 3's estimate is 0.40 log units below it; measured number inside the range.
By their numbers in this assay, from the lowest: compound 2; then compound 1; then compound 3.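

In this assay, methyl in place of methoxy at this position gives a number 0.80 log units higher from compound 2 to compound 3 (beyond the scatter), and methyl in place of chloro gives a number 0.40 log units higher from compound 1 to compound 3 (beyond the scatter). The three groups on this aromatic carbon now fall in a single order, with methoxy lowest, chloro in the middle and methyl highest. No supporting data bear on why they fall in this order. On these data alone, it remains open where an amine, a carboxylic acid or a longer chain such as ethoxy would fall at this position, and whether the same order would hold on another core.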